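Swapping an aromatic ring on a long-chain amide

A few compounds are considered here, and "the series" means these few. Any claim that something is new, unique, unknown or untested is made for them only; others in the source may bear on it.

Compound 1 `CCCCCCCCCCCCCCNC(=O)[C@@H](NC(=O)c1nccc2ccccc12)[C@@H](C)O` joins a long saturated chain, through an amide, to a small amino-acid-like centre that carries a second amide bearing an aromatic group. In a functional assay on MCF7 cells (Homo sapiens) for cytotoxicity, read by MTT assay, with a stated time of 48 h (on this read-out lower numbers stand for stronger inhibition and higher numbers for weaker inhibition), compound 1 gives 22800 nM. Compound 2 `CCCCCCCCCCCCCCNC(=O)[C@@H](NC(=O)c1cc2ccccc2[nH]1)[C@@H](C)O` differs from compound 1 only by 1H-indol-2-yl in place of isoquinolin-1-yl on a carbonyl carbon, and in this assay compound 2 gives 15100 nM, so the change made a 1.5-fold lower number from compound 1 to compound 2 (0.18 log units; within the scatter). Compound 3 `CCCCCCCCCCCCCCCCCCNC(=O)[C@@H](NC(=O)c1nccc2ccccc12)[C@@H](C)O` differs from compound 1 by butyl in place of hydrogen on a saturated chain carbon, ten or more bonds along the chain from an amide-type nitrogen; in this assay compound 3 gives 30800 nM, which is a 1.4-fold higher number from compound 1 to compound 3 (0.13 log units; within the scatter). Compound 2 and compound 3 differ in both places at once, and their two numbers lie somewhat further apart.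

Compound 4 `CCCCCCCCCCCCCCCCCCNC(=O)[C@@H](NC(=O)c1cc2ccccc2[nH]1)[C@@H](C)O` is not yet measured. It differs from compound 3 by 1H-indol-2-yl in place of isoquinolin-1-yl on a carbonyl carbon, the same change that separates compound 1 from compound 2, now made on the longer chain. Because that earlier step a 1.5-fold lower number from compound 1 to compound 2 (0.18 log units; within the scatter) stayed within the scatter, compound 4 is expected to show a step of similar size, namely a 1.5-fold lower number from compound 3 to compound 4 (0.19 log units; within the scatter). The estimate for compound 4 in this assay is 20000 nM, with a likely span from 10000 nM to 45000 nM.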

Compound 4, half-maximal inhibitory concentration: 35700 nM
Compound 4: middle estimate off by 1.8-fold (0.25 log units), on the low side, and the stated range covers the measured number.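

Among these compounds, on the longer chain, the swap to 1H-indol-2-yl gives a 1.2-fold higher number from compound 3 to compound 4 (0.06 log units; within the scatter), and this step agrees with the one seen on the shorter chain: the same change on two cores in this assay, a 1.5-fold lower number (0.18 log units; within the scatter) from compound 1 to compound 2 and a 1.2-fold higher number (0.06 log units; within the scatter) from compound 3 to compound 4, 1.8-fold (0.24 log units) apart, within the scatter of two such steps Adding butyl to the chain of the 1H-indol-2-yl compound gives a 2.4-fold higher number from compound 2 to compound 4 (0.37 log units; beyond the scatter), and this step also agrees with its counterpart on the isoquinolin-1-yl core: the same change on two cores in this assay, a 1.4-fold higher number (0.13 log units; within the scatter) from compound 1 to compound 3 and a 2.4-fold higher number (0.37 log units; beyond the scatter) from compound 2 to compound 4, 1.8-fold (0.24 log units) apart, within the scatter of two such steps In this assay, then, each change carries from one core to the other with no difference that stands out from the scatter, but this rests on only two pairs per change, the ring swap has no clear direction on either core, and nothing here shows that the steps are truly equal or would hold on other cores.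

On these data alone, it remains open whether a still longer chain would continue the step seen with butyl. As far as these compounds go, it is equally open how an amine or a carboxylic acid in place of the aromatic group would change the number.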